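Swapping acetoxymethyl for isopropyl on the chain

This account rests on a few compounds, and the source may have more. Where it says the series, first, only, none or still open, it means among the compounds named here.

Compound 1 `COc1ccc(C(=O)/C(=C/c2ccc(Cl)cc2Cl)CCOC(C)=O)cc1` is the only one of the three measured compounds to return a number: in a functional assay on MCF7 cells (Homo sapiens) for inhibition, read by XTT assay, with a stated time of 48 h (a lower number here means a stronger inhibitor, a higher number a weaker inhibitor), compound 1 gives 83400 nM. Compound 2 `CCC(/C=C(\CCOC(C)=O)C(=O)c1ccc(OC)cc1)CC` gives > 100000 nM in this assay, which is a limit rather than a number. Compound 3 `COc1ccc(C(=O)/C(=C/c2ccc(Cl)cc2)CCOC(C)=O)cc1` gives > 100000 nM in this assay, again a limit. Compound 4 `COc1ccc(C(=O)/C(=C/c2ccc(Cl)cc2Cl)CC(C)C)cc1` differs from compound 1 by isopropyl in place of acetoxymethyl on a saturated chain carbon bound to a double-bonded chain carbon. The measured steps touch other places: an at least 1.1-fold higher number from compound 1 to compound 2 (0.07 log units; that floor lies within the scatter) and an at least 1.1-fold higher number from compound 1 to compound 3 (0.07 log units; that floor lies within the scatter), both capped by the limit of > 100000 nM in this assay, at which 2 of the 3 values shown sit. Neither alters the saturated chain carbon, so they give no direction for this change. The expected step is a 1.0-fold lower number from compound 1 to compound 4 (0.02 log units; within the scatter) in this assay, no larger than the usual scatter. The estimate for compound 4 is 80000 nM, between 30000 nM and 220000 nM.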

Compound 4, half-maximal inhibitory concentration: > 100000 nM
Compound 4: a limit, no number; the forecaster's own chance of this, stated with the estimate: 45%; middle value at least 1.2-fold (0.09 log units) from the limit.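

At the saturated chain carbon, compound 4 gives a limit in this assay and not a number. Isopropyl in place of acetoxymethyl gives an at least 1.1-fold higher number from compound 1 to compound 4 (0.07 log units; that floor lies within the scatter), so this change shows no gain in inhibition at this position, and the true size of the step stays hidden. With this result, only compound 1 still gives a number: the limit of > 100000 nM in this assay, at which 3 of the 4 values shown sit.

As far as these compounds go, it remains open whether an amine, a carboxylic acid or a longer chain at this carbon would give a number in this assay at all.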